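Replacing the propargylamino group of compound 3

This account rests on a few compounds, and the source may have more. Where it says the series, first, only, none or still open, it means among the compounds named here.

In a functional assay on MCF7 cells (Homo sapiens), read by MTT assay, with a stated time of 48 h (a higher number here means a weaker inhibitor, a lower number a stronger inhibitor), compound 1 `CCN(CC)CCCNC(=O)c1ccc(C(CC)(CC)c2ccc(OCC(=O)C(C)(C)C)c(C)c2)n1CC` gives 530 nM. Compound 2 `CCN(CC)CCCNC(=O)c1ccc(C(CC)(CC)c2ccc(OCC(O)C(C)(C)C)c(C)c2)n1CC` gives 190 nM. That step is a 2.8-fold lower number from compound 1 to compound 2 (0.45 log units; beyond the scatter).

Compound 3 `C#CCNC(=O)c1ccc(C(CC)(CC)c2ccc(OCC(O)C(C)(C)C)c(C)c2)n1CC` gives > 50000 nM, which is a limit and not a number. On the numbers shown, its standing amounts to this: the limit of > 50000 nM in this assay, at which 1 of the 3 values shown sits.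

Compound 4 `CCn1c(C(=O)N(CCC#N)CCC#N)ccc1C(CC)(CC)c1ccc(OCC(O)C(C)(C)C)c(C)c1` differs from compound 3 as follows: a group of 9 heavy atoms (6 carbon, 3 nitrogen; no ring) in place of a group of 4 heavy atoms (3 carbon, 1 nitrogen; no ring), on a carbonyl carbon. The change sits on a carbonyl carbon.

The modest first step concerns another part of the structure and bears little on this change. The closer precedent is an at least 260-fold higher number from compound 2 to compound 3 (2.42 log units; beyond the scatter), the step in which the 2-(diethylamino)ethyl group left. Compound 4 does not regain that group, so little recovery is expected.

The expected step in this assay is small and toward a lower number, if it can be resolved at all: an at least 1.6-fold lower number from compound 3 to compound 4 (0.22 log units; that floor lies within the scatter). A result at the limit would not be surprising.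

For compound 4 the estimated value is 30000 nM, with an expected range of 8000 nM to 50000 nM.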

Compound 4, half-maximal inhibitory concentration: 480 nM
Beside the measured number, compound 4's estimate is 63-fold (1.80 log units) above it, and the stated range ends above it.
By their numbers in this assay, from the lowest: compound 2; then compounds 4 and 1 (each within the scatter of the next). At a limit, above all of these: compound 3.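

Compound 3 holds only a limit and not a number: the limit of > 50000 nM in this assay, at which 1 of the 4 values shown sits.

On the carbonyl carbon in this assay, the group with two nitrile arms and no amide hydrogen gives an at least 100-fold lower number from compound 3 to compound 4 (2.01 log units; beyond the scatter), so the loss seen with the propargylamino group is not fixed by the absence of a diethylamino group. That group's replacement costs only a 2.5-fold higher number from compound 2 to compound 4 (0.40 log units; beyond the scatter), which shows that in these compounds a value in the range of compound 2 can be reached without a diethylamino group or an amide hydrogen.

What the compounds shown leave open is whether the nitrile ends matter at all, or whether a plain dipropylamino group on the carbonyl carbon would do the same. Also open, from the compounds shown here alone, is whether one cyanoethyl arm that keeps the amide hydrogen, or a morpholine in its place, would hold this level.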